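Swapping benzyl for hexyl on the shared core

The source may report more compounds than this note shows. Statements on the series, on what has been measured and on what is new or still open speak of the compounds shown alone.

Going by the values given here, compound 2 `OC[C@H]1OC(n2cnc3c(NCc4ccccc4)nccc32)[C@H](O)[C@@H]1O` is the only one of three compounds to give an actual number in a functional assay on EL4 cells (Mus musculus) for inhibition, tested at 100 uM (a lower number here means less inhibition, a higher number more inhibition at the concentration tested (going by the name of the read-out)), where compound 2 shows 5%. Compound 1 `OCCNc1[nH]ccc2ncnc1-2` reaches only a limit of this assay, namely < 5%. Compound 3 `[O-][n+]1ccc2c(c1)ncn2C1O[C@H](CO)[C@@H](O)[C@H]1O` likewise stops at a limit, < 5%. the limit of < 5% in this assay, at which 2 of the 3 values shown sit, frames the whole set: the lone number sits right at the edge of that limit. Compound 4 `CCCCCCNc1nccc2c1ncn2C1O[C@H](CO)[C@@H](O)[C@H]1O` differs from compound 2 by pentyl in place of phenyl on a saturated chain carbon bound to a nitrogen on an aromatic ring. Among the compounds with values here, no measured pair separates this exchange, so it carries no precedent. With every value near the floor, compound 4 is expected to give 5%, between 0% and 15%. The expected step of no change at the digits printed from compound 2 to compound 4 (within the scatter) is estimated to be none beyond the scatter.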

Compound 4, a percentage reported as inhibition, at one concentration (the size of the read-out at that concentration, not a potency): 14%
Compound 4: middle estimate off by 9 percentage points, on the low side, within the range that was stated.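

The first exchange read at this position, benzylamino to hexylamino, gives in this assay a number 9 percentage points higher from compound 2 to compound 4 (within the scatter). The aromatic ring of the phenyl can thus give way to an open pentyl with the two compounds still within the scatter of each other, so this read-out does not separate them. Compound 4 gives an actual number, yet the set stays close to its floor: the limit of < 5% in this assay, at which 2 of the 4 values shown sit.

From the compounds shown here alone, whether a longer chain or an amine at the end of the hexyl chain would move the read-out beyond the scatter stays open. Read at one concentration, these values give no potency for any compound.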